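Trifluoromethyl in place of chloro on the aryl of compound 1

A few compounds are considered here, and "the series" means these few. Any claim that something is new, unique, unknown or untested is made for them only; others in the source may bear on it.

Of the compounds shown here, three of the shared core have been measured in a functional assay on CHO cells for antagonist activity at Glucagon receptor (Homo sapiens), read by cAMP accumulation, with stated times of 30 min and 45 min; on this read-out higher numbers stand for weaker inhibition and lower numbers for stronger inhibition. Compound 1 `CC(C)(C)[C@H]1CC[C@]2(CC1)N=C(c1ccc(Cl)cc1)C(=O)N2Cc1ccc(C(=O)NCCC(=O)O)cc1` gives 1400 nM. Compound 2 `C[C@H](c1ccc(C(=O)NCCC(=O)O)cc1)N1C(=O)C(c2ccc(F)cc2)=N[C@]12CC[C@@H](C(C)(C)C)CC2` gives 430 nM, a lower number than compound 1 by more than the scatter. Compound 3 `CC(C)(C)CC[C@H](c1ccc(C(=O)NCC(=O)O)cc1)N1C(=O)C(c2cc(Cl)cc(Cl)c2)=N[C@]12CC[C@@H](C(C)(C)C)CC2` gives 2700 nM, which lies within the scatter of compound 1. Compound 1 thus stands at the second highest of the three numbers. Compound 4 `CC(C)(C)[C@H]1CC[C@]2(CC1)N=C(c1ccc(C(F)(F)F)cc1)C(=O)N2Cc1ccc(C(=O)NCCC(=O)O)cc1` has not been measured; it differs from compound 1 in one place: trifluoromethyl in place of chloro on an aromatic carbon. Going by the values given here, no measured pair shows this change, so its size is open. The step of a 1.4-fold lower number from compound 1 to compound 4 (0.15 log units; within the scatter) is expected to stay within the scatter, if anything downward. The estimate for compound 4 is 1000 nM, in a range from 350 nM to 3000 nM.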

Compound 4, half-maximal inhibitory concentration: 800 nM
Compound 4: the middle estimate sits 1.3-fold (0.10 log units) above what was measured, within the range that was stated.
By their numbers in this assay, from the lowest: compounds 2, 4, 1 and 3 (each within the scatter of the next, the first and the last beyond it).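

In this assay, going by these compounds alone, this is the first pair of compounds differing in one place, and it gives a 1.8-fold lower number from compound 1 to compound 4 (0.24 log units; within the scatter). On the core of compound 1, the aromatic carbon bearing chloro therefore accepts trifluoromethyl with no change beyond the scatter, though one pair cannot show a trend. No measurement on these two groups bears on this result.

On these data alone, whether a nitrile, a methoxy group or an amine on this carbon would stay within the scatter remains open. So does whether the same exchange would give a similar step in compound 2.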